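The source may hold more compounds than are shown below. What is called first, only, known or untested is meant among the compounds shown, and "the series" means these compounds.

In a functional assay on MCF7 cells (Homo sapiens) for cytotoxicity, read by ELISA, with a stated time of 4 days (on this read-out higher numbers stand for weaker inhibition and lower numbers for stronger inhibition), compound 1 `Cc1ccsc1-c1cc(-c2ccco2)cc(-c2ccc(Cl)cc2)n1` reads 890 nM and compound 2 `Clc1ccc(-c2cc(-c3ccco3)cc(-c3ccc(Cl)s3)n2)cc1` reads 1520 nM within the scatter of it, while compound 3 `Cc1ccsc1-c1cc(-c2ccc(Cl)o2)cc(-c2cccc(Cl)c2)n1` reads 18800 nM and so lies well above both. Compound 4 `Clc1ccc(-c2cc(-c3ccc(Cl)o3)cc(-c3ccc(Cl)s3)n2)cc1` differs from compound 2 by chloro in place of hydrogen on an aromatic carbon which turns furan-2-yl into 5-chlorofuran-2-yl. Going by the values given here, the one measured step (a 1.7-fold higher number from compound 1 to compound 2 (0.23 log units; within the scatter)) lies elsewhere on the molecule and does not bear directly on this change. Only compound 3 (18800 nM) carries 5-chlorofuran-2-yl, yet it also differs from compound 2 in other places, so it points only loosely toward a higher number. The expected change is therefore modest and upward (a 2.0-fold higher number from compound 2 to compound 4 (0.30 log units; within the scatter)) with wide uncertainty. For compound 4 the estimated value is 3000 nM (800 nM to 12000 nM).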

Compound 4, half-maximal inhibitory concentration: 12600 nM
For compound 4 the middle estimate is 4.2-fold (0.62 log units) below the measured one, and the stated range ends below it.
By their numbers in this assay, from the lowest: compounds 1 and 2 (each within the scatter of the next); then compounds 4 and 3 (each within the scatter of the next).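

In this assay, chloro in place of hydrogen, turning furan-2-yl into 5-chlorofuran-2-yl, gives a step beyond the scatter: an 8.3-fold higher number from compound 2 to compound 4 (0.92 log units; beyond the scatter). Going by these compounds alone, the only earlier step lay elsewhere on the molecule and within the scatter, so this is the first sign that this aromatic carbon next to the ring oxygen is sensitive to change, with one chlorine weakening inhibition. Nothing available accounts for the rise. As far as these compounds go, whether a methyl group, a methoxy group or an amine at this place would shift the number likewise stays open. So does whether the same change would give a similar step in compound 1.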